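From dimethylamino to nitro on compound 1

The source may report more compounds than this note shows. Statements on the series, on what has been measured and on what is new or still open speak of the compounds shown alone.

Compound 1 (`CN(C)c1ccc(/C=C/C(=O)c2ccc3c(c2O)C=CC(C)(C)O3)cc1`) is the starting point. In an ADME assay on Vero cells (Chlorocebus sabaeus) for cytotoxicity, read by MTT assay, with a stated time of 72 h (a lower number here means that less compound is tolerated, a higher number that more compound is tolerated), compound 1 gives > 400000 nM, which is a limit of the assay and not a number.

Two relatives share the core of compound 1 and do give numbers. Compound 2 (`CC1(C)C=Cc2c(ccc(C(=O)/C=C/c3ccc(Cl)c(Cl)c3)c2O)O1`) gives 142000 nM and compound 3 (`CCOc1cc(/C=C/C(=O)c2ccc3c(c2O)C=CC(C)(C)O3)ccc1F`) gives 185000 nM, two values within the usual scatter of each other.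

Compound 4 (`CC1(C)C=Cc2c(ccc(C(=O)/C=C/c3ccc([N+](=O)[O-])cc3)c2O)O1`) has not yet been measured. It has nitro in place of dimethylamino on an aromatic carbon, para to a large group (nitro in place of dimethylamino on an aromatic carbon). Among the measured compounds shown here, no measured pair isolates a single change, so any forecast here is rough.

Only compound 1 carries dimethylamino, so compound 4 is expected to resemble compound 2 at 142000 nM and compound 3 at 185000 nM. The expected step is an at least 2.6-fold lower number from compound 1 to compound 4 (0.42 log units; beyond the scatter), meaning less compound tolerated. For compound 4 the estimated value is 150000 nM, with an expected range of 60000 nM to 380000 nM.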

Compound 4, half-maximal cytotoxic concentration: 106000 nM
Estimate against measurement, compound 4: 1.4-fold (0.15 log units) above; the measured number falls inside the stated range.
By their numbers in this assay, from the lowest: compounds 4, 2 and 3 (each within the scatter of the next). At a limit, above all of these: compound 1.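

Among the compounds shown here, this is the first pair that differs in one place, so the exchange of dimethylamino for nitro, on an aromatic carbon para to a large group, can now be read on its own. In this assay the exchange gives an at least 3.7-fold lower number from compound 1 to compound 4 (0.57 log units; beyond the scatter), which shows that the group at this position matters for how much compound the cells tolerate. The full size of the step stays unknown because compound 1 stands at a limit of the assay and not at a number: the limit of > 400000 nM in this assay, at which 1 of the 4 values shown sits.

The compounds shown leave open how a plain amino group, a methoxy group or a carboxylic acid would behave at this position. A single pair also cannot tell whether losing dimethylamino or gaining nitro drives the step.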